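Compound 3 to compound 4: diethylamino to piperidin-1-yl

A few compounds are considered here, and "the series" means these few. Any claim that something is new, unique, unknown or untested is made for them only; others in the source may bear on it.

- compound 1 `CCn1c(N)c(-c2nc3ccccc3[nH]2)c2nc(C#N)c(C#N)nc21`: > 50000 nM
- compound 2 `CN(C)CCCn1c(N)c(-c2nc3ccccc3[nH]2)c2nc(C#N)c(C#N)nc21`: 25900 nM
- compound 3 `CCN(CC)CCCn1c(N)c(-c2nc3ccccc3[nH]2)c2nc(C#N)c(C#N)nc21`: 3150 nM

The value of compound 1 is a limit, not a number. In a functional assay on HeLa cells (Homo sapiens) for antiproliferative activity, read by MTT assay, with a stated time of 48 h (a higher number here means a weaker inhibitor, a lower number a stronger inhibitor), compound 3 gives 3150 nM, the lowest number measured. Compound 4 `N#Cc1nc2c(-c3nc4ccccc4[nH]3)c(N)n(CCCN3CCCCC3)c2nc1C#N` carries piperidin-1-yl in place of diethylamino on a saturated chain carbon, three bonds along the chain from an aromatic nitrogen. The closest measured change at this place is an 8.2-fold lower number from compound 2 to compound 3 (0.91 log units; beyond the scatter). The wider step is an at least 15-fold lower number from compound 1 to compound 3 (1.20 log units; beyond the scatter). Both rest on few compounds, and neither tests a ring. A smaller step than the closest one is expected in this assay, with a slight fall in the number if any. The expected step is a 1.3-fold lower number from compound 3 to compound 4 (0.10 log units; within the scatter). For compound 4 the estimated value is 2500 nM, with an expected range of 900 nM to 7000 nM.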

Compound 4, half-maximal inhibitory concentration: 6680 nM
The estimate for compound 4 lay 2.7-fold (0.43 log units) below the measured number; the measured number falls inside the stated range.
By their numbers in this assay, from the lowest: compound 3; then compound 4; then compound 2. At a limit, above all of these: compound 1.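

In this assay the only ring at this place, piperidin-1-yl, does not improve on the open diethylamino group (a 2.1-fold higher number from compound 3 to compound 4 (0.33 log units; beyond the scatter)). It still stays ahead of dimethylamino (a 3.9-fold lower number from compound 2 to compound 4 (0.59 log units; beyond the scatter)), so a ring is not needed for the gain over the smallest amine. Against the chain without an amine the step is only a floor (an at least 7.4-fold lower number from compound 1 to compound 4 (0.87 log units; beyond the scatter)), since the value of compound 1 is a limit: the limit of > 50000 nM in this assay, at which 1 of the 4 values shown sits.

Open, as far as these compounds go, is whether the loss from compound 3 to compound 4 belongs to ring closure as such. Pyrrolidin-1-yl, morpholin-4-yl or a longer chain would test this.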